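Swapping Furan for Thiophene in a Nitrile Series

This account rests on a few compounds, and the source may have more. Where it says the series, first, only, none or still open, it means among the compounds named here.

Measured in a functional assay on CCRF-CEM cells (Homo sapiens) for antiproliferative activity, read by resazurin assay, with a stated time of 72 h; on this read-out lower numbers stand for stronger inhibition and higher numbers for weaker inhibition:
Compound 1 `N#Cc1c(-c2ccco2)nc2c(c(-c3ccccc3)nn2-c2ccccc2)c1-c1ccc(O)cc1`: 23900 nM
Compound 2 `COc1cc(-c2c(C#N)c(-c3ccco3)nc3c2c(-c2ccccc2)nn3-c2ccccc2)ccc1O`: 36500 nM
Compound 3 `COc1ccc(-c2c(C#N)c(-c3ccccc3)nc3c2c(-c2ccccc2)nn3-c2ccccc2)cc1OC`: its value is a limit of this assay, > 25000 nM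

Compound 2 stands with compound 1 among the two numbers shown; the only counted step, a 1.5-fold higher number from compound 1 to compound 2 (0.18 log units; within the scatter), separates them. Compound 3 sits at a limit, (the limit of > 25000 nM in this assay, at which 1 of the 3 values shown sits). Compound 4 `COc1cc(-c2c(C#N)c(-c3cccs3)nc3c2c(-c2ccccc2)nn3-c2ccccc2)ccc1O` arises from compound 2 by thiophen-2-yl in place of furan-2-yl on an aromatic carbon. Going by the values given here, no measured step touches this exchange: the one step known concerns the methoxy group, not the five-membered ring. With nothing to point either way, the change from compound 2 to compound 4 is expected to stay within the scatter, a 1.0-fold lower number from compound 2 to compound 4 (0.02 log units; within the scatter). Compound 4 is therefore estimated at 35000 nM, with a range from 15000 nM to 80000 nM.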

Compound 4, half-maximal inhibitory concentration: 37300 nM
The estimate for compound 4 lay 1.1-fold (0.03 log units) below the measured number; the range from low to high includes it.
By their numbers in this assay, from the lowest: compounds 1, 2 and 4 (each within the scatter of the next).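

In this assay, going by these compounds alone, thiophen-2-yl in place of furan-2-yl on this carbon, next to the ring nitrogen and ortho to a cyano group, gives a 1.0-fold higher number from compound 2 to compound 4 (0.01 log units; within the scatter), the only counted step at this position. The two five-membered rings therefore cannot be told apart here. Nothing measured explains this result. As far as these compounds go, whether an amine or a morpholine ring on this carbon would give a number beyond the scatter remains open. So does whether the same exchange would read alike on compound 1, which lacks the methoxy group.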